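Taking the methoxy group off compound 1

The source may hold more compounds than are shown below. What is called first, only, known or untested is meant among the compounds shown, and "the series" means these compounds.

In a physicochemical assay for solubility (a lower number here means a less soluble compound, a higher number a more soluble compound), compound 1 `CNC(=O)c1cc(C(=O)N[C@H]2[C@@H]3COC[C@@H]32)cc2c1OC[C@H]2c1cccc(OC)c1` gives >= 186 ug/mL as a limit and not a number. Compound 2 `CNC(=O)c1cc(C(=O)NC2CC2)cc2c1OC[C@H]2c1cccc(OC)c1` gives >= 161 ug/mL as a limit too. Compound 3 `CNC(=O)c1cc(C(=O)N[C@H]2[C@@H]3C[C@H](O)C[C@@H]32)cc2c1OC[C@@]2(C)c1ccccc1` likewise gives >= 151 ug/mL as a limit. Compound 1 therefore stands without an exact value, and so do the two others.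

Compound 4 `CNC(=O)c1cc(C(=O)N[C@H]2[C@@H]3COC[C@@H]32)cc2c1OC[C@H]2c1ccccc1` follows from compound 1 by a single change (hydrogen in place of methoxy on an aromatic carbon) with hydrogen in place of methoxy on an aromatic carbon, so that 3-methoxyphenyl becomes phenyl. Among the compounds with values here, only one measured step is available, a step that the two limits leave unreadable from compound 1 to compound 2 on an amide-type nitrogen. It concerns another place in the structure and its size cannot be read, so it offers no measure for the loss of the methoxy group. With so little to go on, no change beyond the usual scatter is expected. The expected change is an at least 1.0-fold lower number from compound 1 to compound 4 (0.02 log units; that floor lies within the scatter) and no more. For compound 4 the estimated value is 175 ug/mL with an expected range from 100 ug/mL to 205 ug/mL in this assessment.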

Compound 4, solubility: >= 165 ug/mL
Compound 4: a limit, no number (the forecaster's own chance of this, stated with the estimate: 70%); the middle value is on the limit's open side.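

In this assay compound 4 gives >= 165 ug/mL, a limit and not a number. Compound 1 also stands only as a limit, so the step from compound 1 to compound 4 cannot be read. The compounds shown leave open whether hydrogen in place of methoxy changes the read-out at all.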